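The compounds below may be only part of what the source reports. "The series", "measured", "known", "first", "only" and "open" are said of these compounds alone.

So far, two compounds have been tested in a functional assay on MIA PaCa-2 cells (Homo sapiens) for inhibition, read by MTT assay, with a stated time of 48 h, tested at 10 uM; on this read-out higher numbers stand for more inhibition of growth at the one concentration tested and lower numbers for less inhibition of growth. In this test, compound 1 (`COc1ccc(COc2cc(O)c3c(=O)cc(C)oc3c2[C@H]2CCN(C)C[C@H]2O)cc1`) gives 15%, and compound 2 (`Cc1oc2c([C@H]3CCN(C)C[C@H]3O)c(O)cc(O)c2c(=O)c1C(O)c1ccccc1Br`) gives 10%. Among the compounds with values here, these two numbers lie within the usual scatter of each other, so compound 2 cannot be told apart from the only other measured compound.

The next compound to be tested is compound 3 (`Cc1oc2c([C@H]3CCN(C)C[C@H]3O)c(O)cc(O)c2c(=O)c1C(O)c1csc([N+](=O)[O-])c1`). It keeps compound 2 intact except for one group: 5-nitrothiophen-3-yl in place of 2-bromophenyl on a saturated chain carbon bound to an aromatic carbon and an oxygen on a saturated carbon. Put simply, 5-nitrothiophen-3-yl stands in place of 2-bromophenyl on a saturated chain carbon bound to an aromatic carbon and an oxygen on a saturated carbon.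

Within the data shown here, no two measured compounds differ in just one place, so the data give no direct guide to this swap. With nothing to point either way, no step beyond the scatter is expected in this assay, and the starting point is compound 2 at 10%. The expected change is a number 5 percentage points higher from compound 2 to compound 3 (within the scatter). For compound 3 the estimated value is 15%, with an expected range from 3% to 35%.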

Compound 3, percent growth inhibition at one concentration: 41%
For compound 3 the middle estimate is 26 percentage points below the measured one; the measured number lies above the stated range.
By their numbers in this assay, from the lowest: compounds 2 and 1 (each within the scatter of the next); then compound 3.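

Within the data shown here, this is the first pair in the set that differs in one place only, so it gives the first direct reading of a change in the molecule. In this assay, 5-nitrothiophen-3-yl in place of 2-bromophenyl, on a saturated chain carbon bound to an aromatic carbon and an oxygen on a saturated carbon, gives a number 31 percentage points higher from compound 2 to compound 3 (beyond the scatter) with the rest of the molecule unchanged, so the group held at this place clearly affects the result. The swap changes the ring, removes the bromine and adds the nitro group all at once, and nothing measured here shows which of these changes matters or why.

From the compounds shown here alone, it remains open whether the gain follows the thiophene ring or the nitro group, which a plain thiophen-3-yl group or a phenyl ring carrying a nitro group at this place would help to separate. Going by these compounds, it is also open whether the nitro group itself is needed, or whether an amine or a nitrile on the thiophene ring would serve equally well.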